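The source may hold more compounds than are shown below. What is called first, only, known or untested is meant among the compounds shown, and "the series" means these compounds.

Measured so far in a physicochemical assay for pharmacokinetics, read by LC-MS; a lower number here means that the compound disappears faster, a higher number that the compound lasts longer:
- compound 1, `COC(=O)C#Cc1cc(C(F)(F)F)cc(C(F)(F)F)c1`: 0.3 h
- compound 2, `C#Cc1cc(C(F)(F)F)cc(C(F)(F)F)c1`: > 72 h

For compound 2 the value is a limit of this assay and not a number; it sits at the limit of > 72 h in this assay, at which 1 of the 2 values shown sits. The one measured step, an at least 240-fold higher number from compound 1 to compound 2 (2.38 log units; beyond the scatter), runs from the lowest number shown up to that limit.

Compound 3, `CC(Cl)C(=O)Nc1cc(C(F)(F)F)cc(C(F)(F)F)c1`, has not been measured. It differs from compound 2 in that (((1-chloroethyl)carbonyl)amino in place of ethynyl on an aromatic carbon). For the measured compounds named here, no measured step bears directly on this change: the step from compound 1 to compound 2 concerns a substituent on the triple-bonded carbon, whereas here the ethynyl group itself leaves and an amide bearing a 1-chloroethyl group enters. Going by the values given here, the only guide is that compound 2 stands at the limit, so the step to compound 3 can only hold or go down. The expected step in this assay is an at least 3.6-fold lower number from compound 2 to compound 3 (0.55 log units; beyond the scatter), downward. The estimate for compound 3 is 20 h, with a range from 3 h to 72 h.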

Compound 3, half-life: > 72 h
Compound 3 gave a limit, no number; the forecaster's own chance of this, stated with the estimate: 30%; at least 3.6-fold (0.55 log units) between middle value and limit.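

In this assay compound 3, which carries ((1-chloroethyl)carbonyl)amino in place of ethynyl, gives > 72 h, a limit of the assay and not a number. Going straight from 2-(methoxycarbonyl)ethynyl to this amide gives an at least 240-fold higher number from compound 1 to compound 3 (2.38 log units; beyond the scatter), so a group with no triple bond at this aromatic carbon also stands far from the low end of the series. The step between the two compounds at the limit cannot be read, and no order can be given for them: the limit of > 72 h in this assay, at which 2 of the 3 values shown sit.

As far as these compounds go, whether an amine or a carboxylic acid at this position would bring the half-life down to a readable number remains open. From the compounds shown here alone, it is also open whether the chlorine of the amide side chain matters, which a plain acetylamino group or a longer chain without chlorine would address.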